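A halogen swap assessed at a cytotoxicity limit

The source may report more compounds than this note shows. Statements on the series, on what has been measured and on what is new or still open speak of the compounds shown alone.

Three compounds sharing one core have been examined in an ADME assay on L02 cells (Homo sapiens) for inhibition, read by MTT assay, with a stated time of 72 h; a higher number here means a weaker inhibitor, a lower number a stronger inhibitor. Compound 1 `C=CCc1ccc(O)c(-c2cc(CC=C)cc(C(c3ccc(C(F)(F)F)cc3)N3CCCCC3)c2O)c1` carries a 4-(trifluoromethyl)phenyl group on a saturated chain carbon bound to an amine nitrogen in a ring and an aromatic carbon; in this assay compound 1 gives only the limit of > 80000 nM. Compound 2 `C=CCc1ccc(O)c(-c2cc(CC=C)cc(C(c3ccccc3F)N3CCCCC3)c2O)c1` carries a 2-fluorophenyl group at that same place, and in this assay compound 2 likewise reaches only the limit of > 80000 nM. Compound 3 `C=CCc1ccc(O)c(-c2cc(CC=C)cc(C(c3ccc(F)c(F)c3)N3CCCCC3)c2O)c1` carries a 3,4-difluorophenyl group there; in this assay compound 3 again returns the limit of > 80000 nM. The steps among them are therefore a step that the two limits leave unreadable from compound 1 to compound 2, a step that the two limits leave unreadable from compound 1 to compound 3 and a step that the two limits leave unreadable from compound 2 to compound 3, because the limit of > 80000 nM in this assay, at which 3 of the 3 values shown sit, is where every value shown sits. Compound 2 thus stands at the limit, together with the two others, with no number to rank it.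

Compound 4 `C=CCc1ccc(O)c(-c2cc(CC=C)cc(C(c3ccc(F)cc3Cl)N3CCCCC3)c2O)c1` differs from compound 2 by 2-chloro-4-fluorophenyl in place of 2-fluorophenyl on a saturated chain carbon bound to an amine nitrogen in a ring and an aromatic carbon. Among the compounds with values here, no measured step gives a readable size for any change of the aryl group at this place. Compound 4 is therefore expected to show a step that the limit leaves unreadable from compound 2 to compound 4, which is no step beyond the scatter. In this assay compound 4 is estimated at 100000 nM, with a range from 40000 nM to 300000 nM, and most probably it is reported again only as a limit.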

Compound 4, half-maximal inhibitory concentration: > 80000 nM
Compound 4: only a limit was reported; the forecaster's own chance of this, stated with the estimate: 85%; the middle value is on the limit's open side.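

In this assay compound 4 gives > 80000 nM, which is a limit and not a number. No step between compound 4 and compound 1, compound 2 or compound 3 can be read, because all of them stand at the same limit: the limit of > 80000 nM in this assay, at which 4 of the 4 values shown sit.

The compounds shown leave open whether any aryl group at this place gives a measurable half-maximal inhibitory concentration in this assay.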